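Methoxy Replaces Pyrrolidinyl on the Shared Core

A few compounds are considered here, and "the series" means these few. Any claim that something is new, unique, unknown or untested is made for them only; others in the source may bear on it.

Three compounds share one core and differ only at one aromatic carbon. Compound 1 `CC(=O)N1CC=C(c2ccn3c(-c4ccc(NC(=O)c5ccc([N+](=O)[O-])o5)cc4)cnc3c2)CC1` gives 410 nM in a functional assay on AGS cells (Homo sapiens) for antiproliferative activity, read by CCK-8 assay, with a stated time of 72 h; on this read-out lower numbers stand for stronger inhibition and higher numbers for weaker inhibition. Compound 2 `CC1(O)CCN(c2ccn3c(-c4ccc(NC(=O)c5ccc([N+](=O)[O-])o5)cc4)cnc3c2)CC1` gives 1530 nM in this assay, and compound 3 `O=C(Nc1ccc(-c2cnc3cc(N4CCCC4)ccn23)cc1)c1ccc([N+](=O)[O-])o1` gives 1240 nM. Among these three, compound 3 holds the second highest number: its nearest neighbour is compound 2, the two lying within the scatter of each other, while a 3.0-fold higher number from compound 1 to compound 3 (0.48 log units; beyond the scatter) is beyond it.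

Compound 4 `COc1ccn2c(-c3ccc(NC(=O)c4ccc([N+](=O)[O-])o4)cc3)cnc2c1` is the next member and has not yet been measured. It differs from compound 3 in one place: methoxy in place of pyrrolidin-1-yl on an aromatic carbon, a group with no ring entering where a five-membered ring stood.

For the measured compounds named here, two measured steps touch this position. a 3.0-fold higher number from compound 1 to compound 3 (0.48 log units; beyond the scatter) and a 1.2-fold lower number from compound 2 to compound 3 (0.09 log units; within the scatter) show that exchanging one ring for another on this carbon moved the number within a modest span. Going by the values given here, no measured step removes the ring altogether, so the outlook for compound 4 rests on that span alone. Compound 4 is expected to remain near compound 3, with a 1.2-fold higher number from compound 3 to compound 4 (0.08 log units; within the scatter) as the estimated step. The estimate for compound 4 in this assay is 1500 nM, with a range from 600 nM to 4000 nM.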

Compound 4, half-maximal inhibitory concentration: 720 nM
For compound 4 the middle estimate is 2.1-fold (0.32 log units) above the measured one, and the stated range covers the measured number.
By their numbers in this assay, from the lowest: compounds 1, 4, 3 and 2 (each within the scatter of the next, the first and the last beyond it).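

For the compounds shown here, compound 4 is the first member without a ring on this aromatic carbon, and in this assay removing the ring costs nothing measurable: the step from the pyrrolidin-1-yl compound (a 1.7-fold lower number from compound 3 to compound 4 (0.24 log units; within the scatter)) leaves the two compounds indistinguishable. Against the 4-hydroxy-4-methylpiperidin-1-yl group the small methoxy group does separate, with a modest step in the favourable direction (a 2.1-fold lower number from compound 2 to compound 4 (0.33 log units; beyond the scatter)), so a ring on this carbon is not needed to reach a number beyond the scatter of compound 2. Compound 1 had stood apart from both compound 2 and compound 3, yet it cannot be told apart from compound 4 (a 1.8-fold higher number from compound 1 to compound 4 (0.24 log units; within the scatter)), which means that its large ring-bearing group is not the only substituent shown that reaches this level.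

Methoxy is the only group without a ring among these compounds, so it remains open whether this result extends to other such groups. A longer chain such as butoxy, or a primary amine on the same carbon, would test that in this assay. Nothing available here accounts for these differences.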